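Pentyl in Place of 4-Bromophenyl on an Aromatic Nitrogen

The source may report more compounds than this note shows. Statements on the series, on what has been measured and on what is new or still open speak of the compounds shown alone.

Measured so far in a functional assay on A549 cells (Homo sapiens) for antiproliferative activity, read by MTT assay; a higher number here means a weaker inhibitor, a lower number a stronger inhibitor:
- compound 1 `CC1(C)CCc2cc(C(=O)/C=C/c3ccc(OCc4cn(-c5ccc(Br)cc5)nn4)cc3)c(O)cc2O1`: 80000 nM
- compound 2 `CCc1ccccc1-n1cc(COc2ccc(/C=C/C(=O)c3cc4c(cc3O)OC(C)(C)CC4)cc2)nn1`: 137000 nM
- compound 3 `CC1(C)CCc2c(ccc(C(=O)/C=C/c3ccc(OCc4cn(-c5ccc(Br)cc5)nn4)cc3)c2O)O1`: 129000 nM

The three values lie within the usual scatter of one another, so compound 3 stands apart from neither of the others in this assay. The next compound, compound 4 `CCCCCn1cc(COc2ccc(/C=C/C(=O)c3ccc4c(c3O)CCC(C)(C)O4)cc2)nn1`, has pentyl in place of 4-bromophenyl on an aromatic nitrogen.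

Among the compounds with values here, only one measured step bears on this change, a 1.7-fold higher number from compound 1 to compound 2 (0.23 log units; within the scatter). There, 2-ethylphenyl took the place of 4-bromophenyl on an aromatic nitrogen, and the size of that step stayed within the scatter. It offers only limited guidance, since it exchanged one ring-bearing group for another and was not measured on the core of compound 3. Within the data shown here, no measured step shows a ring-bearing group on that nitrogen giving way to an open chain, so the range has to stay wide. On this evidence, no step beyond the scatter is expected in either direction. The estimated change is a 1.2-fold lower number from compound 3 to compound 4 (0.07 log units; within the scatter). For compound 4 the expected value is 110000 nM, within an estimated range of 45000 nM to 250000 nM.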

Compound 4, half-maximal inhibitory concentration: 48600 nM
Compound 4: middle estimate off by 2.3-fold (0.35 log units), on the high side; measured number inside the range.
By their numbers in this assay, from the lowest: compounds 4, 1, 3 and 2 (each within the scatter of the next, the first and the last beyond it).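

In this assay, within the data shown here, the open chain produced the first step on this nitrogen that lies beyond the scatter: on the core of compound 3, pentyl in place of 4-bromophenyl gave a 2.7-fold lower number from compound 3 to compound 4 (0.42 log units; beyond the scatter) and so a stronger inhibitor. Among these compounds, the only earlier step at this position (a 1.7-fold higher number from compound 1 to compound 2 (0.23 log units; within the scatter)) exchanged one ring-bearing group for another on the core of compound 1 and stayed within the scatter, so the group on this nitrogen had not yet been seen to shift the number. Compound 4 now shows that a group with no ring can stand here without any loss of activity on the core of compound 3, though the data shown offer no explanation for the step.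

On these data alone, it remains open whether pentyl would give a similar step on the core of compound 1, and whether the difference follows from the open chain itself or from the departure of 4-bromophenyl. A shorter chain such as propyl, a longer chain such as octyl, or a pentyl chain ending in an amine could show how far this change extends.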